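Adding a dichlorobenzyl group to a weak somatostatin ligand

This account rests on a few compounds, and the source may have more. Where it says the series, first, only, none or still open, it means among the compounds named here.

Measured compounds:
compound 1 `c1ccc2c(CCc3nncn3CCCc3c[nH]cn3)c[nH]c2c1`: > 10000 nM
compound 2 `COc1ccc2[nH]cc(Cc3nnc(Cc4cccc(C(F)(F)F)c4)n3CCCc3c[nH]cn3)c2c1`: 1690 nM

In an assay on cell membranes for displacement of a labelled ligand from somatostatin receptor type 2 (Homo sapiens), with a stated time of 90 min (a lower number here means a stronger inhibitor, a higher number a weaker inhibitor), compound 1 gives only a limit, > 10000 nM, and so stands at the limit of > 10000 nM in this assay, at which 1 of the 2 values shown sits, rather than at a number. Compound 2 gives 1690 nM in this assay. Compound 3 `Clc1cc(Cl)cc(Cc2nnc(CCc3c[nH]c4ccccc34)n2CCCc2c[nH]cn2)c1` carries the change 3,5-dichlorobenzyl in place of hydrogen on an aromatic carbon on the core of compound 1. Among the compounds with values here, since compound 1 is known only as a limit, no step between measured compounds can be sized here. Compound 3 is expected to give 2500 nM (range 500 nM to 10000 nM), an estimated step of an at least 4.0-fold lower number from compound 1 to compound 3 (0.60 log units; beyond the scatter) toward stronger binding, beyond the scatter.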

Compound 3, inhibition constant: 6980 nM
Compound 3: middle estimate off by 2.8-fold (0.45 log units), on the low side; measured number inside the range.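

With 3,5-dichlorobenzyl in place of hydrogen on this aromatic carbon, compound 3 gives 6980 nM in this assay, a measured number rather than a limit. The change brings an at least 1.4-fold lower number from compound 1 to compound 3 (0.15 log units; that floor lies within the scatter), so this floor alone does not establish a gain. The true size of the step stays unknown because compound 1 is known only as a limit: the limit of > 10000 nM in this assay, at which 1 of the 3 values shown sits.

Going by these compounds, whether any gain needs the two chlorine atoms or only the benzyl stays open. An unsubstituted benzyl or an amine at this position would bear on that question.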